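The compounds below may be only part of what the source reports. "The series", "measured", "known", "first", "only" and "open" are said of these compounds alone.

Measured so far:
compound 1 `CC(C)(O)CNCC(=O)N1CCc2ccccc2C1C1CCCCC1` gives 7.7%
compound 2 `CC[C@@H](O)CNCC(=O)N1CCc2ccccc2C1C1CCCCC1` gives 19%

In a functional assay on the whole organism (strain ddY) with Mus musculus as the target, in the formalin test, at a dose of 100 mg/kg by the oral route (a higher number here means more inhibition at the dose given (going by the name of the read-out), a lower number less inhibition), compound 2 stands highest of the two numbers, separated from compound 1 by the step of a number 11.3 percentage points higher from compound 1 to compound 2 (beyond the scatter). Compound 3 `CC[C@H](O)CNCC(=O)N1CCc2ccccc2C1C1CCCCC1` differs from compound 2 as follows: the two compounds have the same atoms and bonds; at least one stereo element is drawn with a configuration in one of them and without one in the other: 1 of 2 stereo elements differ; a stereocentre at a saturated chain carbon is drawn R in compound 2 and S in compound 3. Within the data shown here, no measured step turns a stereocentre alone; the only known step, a number 11.3 percentage points higher from compound 1 to compound 2 (beyond the scatter), swaps the group on that chain carbon rather than its configuration, so it bears only loosely here. Compound 3 is therefore expected to stay within the scatter of compound 2, a step of a number 3 percentage points lower from compound 2 to compound 3 (within the scatter). Compound 3 is estimated at 16%, ranging from 0% to 34%.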

Compound 3, a percentage reported as inhibition, in the whole organism at one dose (the size of the read-out at that dose, not a potency): 27%
For compound 3 the middle estimate is 11 percentage points below the measured one, within the range that was stated.
By their numbers in this assay, from the lowest: compound 1; then compounds 2 and 3 (each within the scatter of the next).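

In this assay turning the stereocentre at the saturated chain carbon gives a number 8 percentage points higher from compound 2 to compound 3 (within the scatter) and so does not separate the two configurations at this position. The 1-hydroxypropyl group also holds its gain over 1-hydroxy-1-methylethyl in the other drawn configuration, with a number 19.3 percentage points higher from compound 1 to compound 3 (beyond the scatter) as the second such step. This reading of configuration carries one caveat: the fact that one of compounds 2 and 3 is drawn with a defined configuration and the other without, at the place where they differ.

The compounds shown leave open whether a longer chain on this carbon would raise the inhibition. They also leave open how an amine or a carboxylic acid in place of the hydroxyl would fare.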